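Methyl to Methoxy on the Amide-Bearing Outer Ring

A few compounds are considered here, and "the series" means these few. Any claim that something is new, unique, unknown or untested is made for them only; others in the source may bear on it.

Compound 1, `Cn1c(=O)c2c(nc(-c3ccc(NC(=O)c4ccccc4)cc3)n2C)n(C)c1=O`: 8900 nM
Compound 2, `COc1ccc(C(=O)Nc2cccc(-c3nc4c([nH]3)c(=O)n(C)c(=O)n4C)c2)cc1`: 16000 nM
Compound 3, `Cc1ccc(C(=O)Nc2cccc(-c3nc4c(c(=O)n(C)c(=O)n4C)n3C)c2)cc1`: 16700 nM

The three compounds share a caffeine-like core carrying an aromatic ring, which in turn carries an amide to a second aromatic ring. In an assay for inhibition of Amine oxidase [flavin-containing] B (Mus musculus), read by fluorescence, with a stated time of 30 min, in the presence of a further agent that is not named here (on this read-out higher numbers stand for weaker inhibition and lower numbers for stronger inhibition), compound 1 gives 8900 nM, compound 2 gives 16000 nM, and compound 3 gives 16700 nM. Compound 3 has the highest of the three numbers, but its gap to compound 2 and its gap to compound 1 both fall within the usual scatter, so no ordering among the three can be read from these values.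

Compound 4, `COc1ccc(C(=O)Nc2cccc(-c3nc4c(c(=O)n(C)c(=O)n4C)n3C)c2)cc1`, has not yet been measured in this assay. It is reached from compound 3 by a single change: methoxy in place of methyl on an aromatic carbon. Compound 2 also carries the methoxy group, though it differs from compound 3 in a second place as well, so its value and that of compound 3 can only be set side by side: they are nearly the same. From compound 3 to compound 4 no step beyond the scatter is expected, in either direction, which a 1.1-fold lower number from compound 3 to compound 4 (0.05 log units; within the scatter) expresses. Compound 4 is therefore estimated at 15000 nM, with a range from 7000 nM to 35000 nM.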

Compound 4, half-maximal inhibitory concentration: 17800 nM
Estimate against measurement, compound 4: 1.2-fold (0.07 log units) below; measured number inside the range.
By their numbers in this assay, from the lowest: compounds 1, 2, 3 and 4 (each within the scatter of the next).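

In this assay, for the compounds shown here, placing methoxy instead of methyl on the outer ring, para to a large group, gives a 1.1-fold higher number from compound 3 to compound 4 (0.03 log units; within the scatter), so this first direct comparison at the position shows no step that can be told apart from the scatter. Compound 4 also provides a one-place comparison at a second site, methyl in place of hydrogen on an aromatic nitrogen, which gives a 1.1-fold higher number from compound 2 to compound 4 (0.05 log units; within the scatter), and this step likewise shows no separation from the scatter. Nothing in the available data bears on this result.

From the compounds shown here alone, whether an amine, a carboxylic acid or a longer chain such as butoxy at the same position would shift the number beyond the scatter remains open. Going by these compounds, compound 1 differs from compound 3 in more than one place, so the effect of leaving this position with only hydrogen also remains open.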